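Working notes: cytotoxicity across the shared core

The source may hold more compounds than are shown below. What is called first, only, known or untested is meant among the compounds shown, and "the series" means these compounds.

Measured in an ADME assay on HEp-2 cells (Homo sapiens) for cytotoxicity, read by CCK-8 assay, with a stated time of 6 days; on this read-out lower numbers stand for higher toxicity in this test and higher numbers for lower toxicity in this test:
- compound 1 `NCCNc1cc(N2CCN(c3cccc(Cl)c3)CC2)nc2ccccc12`: 6400 nM
- compound 2 `NCCNc1cc(N2CCN(C(=O)C3(c4ccccc4)CCCC3)CC2)nc2ccccc12`: the value for compound 2 is a limit of the assay, > 100000 nM
- compound 3 `NCCNc1cc(N2CCN(c3ccccc3Cl)CC2)nc2ccccc12`: 20800 nM

Compound 2 stands apart from compounds 1 and 3: in this assay only a limit is known for compound 2, (the limit of > 100000 nM in this assay, at which 1 of the 3 values shown sits), and no number beneath it. Compound 4 `NCCNc1cc(N2CCN(C(=O)C3(c4ccccc4)CC3)CC2)nc2ccccc12` differs from compound 2 by 1-phenylcyclopropyl in place of 1-phenylcyclopentyl on a carbonyl carbon; the group that leaves and the group that enters each carry a six-membered aromatic ring of carbon only, and the change is from a five-membered to a three-membered non-aromatic ring of carbon only.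

Within the data shown here, the single measured step, a 3.3-fold higher number from compound 1 to compound 3 (0.51 log units; beyond the scatter), concerns the substituent on an amine nitrogen in a ring, not the carbonyl carbon, so it does not bear on this change. Among the measured compounds shown here, no measured step spans a change at the carbonyl carbon. Compound 4 is therefore expected to stay near the limit, with the step of a number no higher from compound 2 to compound 4 (the limit leaves the size open) expected to be none beyond the scatter. The estimate for compound 4 in this assay is 100000 nM, ranging from 30000 nM to 300000 nM.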

Compound 4, half-maximal cytotoxic concentration: > 100000 nM
Compound 4 gave a limit, no number; the forecaster's own chance of this, stated with the estimate: 60%; the middle value sits exactly at the limit.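

In this assay, compound 2 and compound 4 each give only a limit of the assay, so no step can be read between them: the limit of > 100000 nM in this assay, at which 2 of the 4 values shown sit.

The compounds shown leave open whether 1-phenylcyclopropyl in place of 1-phenylcyclopentyl on a carbonyl carbon changes the read-out at all.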